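The compounds below may be only part of what the source reports. "The series", "measured", "known", "first", "only" and "open" are said of these compounds alone.

Working notes on the series. Compound 1 `COc1ccc(/C=C/C(=O)c2ccccc2NC(=O)NS(=O)(=O)c2ccc(C)cc2)cc1OC` and compound 2 `Cc1ccc(S(=O)(=O)NC(=O)Nc2ccccc2C(=O)/C=C/c2cccc(O)c2)cc1` share the same core and differ only in the aryl group on the double-bonded chain. In an ADME assay on the whole organism for cytotoxicity, with Artemia salina as the target, with a stated time of 24 h (a lower number here means that less compound is needed, a higher number that more compound is needed for the effect), compound 1 gives 12.9 ug/mL, and compound 2 gives 39.3 ug/mL. Going by the values given here, compound 2 therefore stands at the higher of the two numbers measured so far, the only measured step being a 3.0-fold higher number from compound 1 to compound 2 (0.48 log units; beyond the scatter), which accompanies the exchange of 3,4-dimethoxyphenyl for 3-hydroxyphenyl.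

Compound 3 `Cc1ccc(S(=O)(=O)NC(=O)Nc2ccccc2C(=O)/C=C/c2cccc(F)c2)cc1` is not yet measured. It differs from compound 2 by fluoro in place of hydroxy on an aromatic carbon. Among the compounds with values here, no measured step swaps hydroxy for fluoro on this ring, so the single step between compound 1 and compound 2 bears on it only as a sign that the aryl substituent shifts the number to a modest extent. A step of a 1.6-fold lower number from compound 2 to compound 3 (0.20 log units; within the scatter) in this assay is expected, with no firm direction beyond the scatter. Compound 3 is estimated at 25 ug/mL, within a range of 10 ug/mL to 70 ug/mL.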

Compound 3, concentration for half-maximal effect: 4.13 ug/mL
The estimate for compound 3 lay 6.1-fold (0.78 log units) above the measured number; the measured number lies below the stated range.
By their numbers in this assay, from the lowest: compound 3; then compound 1; then compound 2.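

In this assay the exchange of hydroxy for fluoro on this aromatic carbon gives a 9.5-fold lower number from compound 2 to compound 3 (0.98 log units; beyond the scatter) and so shows that this one substituent can move the number well beyond the scatter. The 3-fluorophenyl group also stands apart from the 3,4-dimethoxyphenyl group, with a 3.1-fold lower number from compound 1 to compound 3 (0.49 log units; beyond the scatter) as the step, which places compound 1 between the two compounds with a single substituent on this ring. Nothing measured on these compounds accounts for the size or direction of these steps.

The compounds shown leave open whether the lower number follows from the presence of fluoro or from the loss of hydroxy. Chloro, an amine or a carboxylic acid on the same aromatic carbon would help separate these two readings.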